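Pyridinyl Urea Swap on Two Related Cores

A few compounds are considered here, and "the series" means these few. Any claim that something is new, unique, unknown or untested is made for them only; others in the source may bear on it.

Compound 1 `O=C(Nc1ccc(F)cc1)N1CCc2ccccc2[C@H]1c1ccc(C(F)(F)F)cc1` was tested in an ADME assay (liver) for metabolic stability, with Liver microsome (Homo sapiens) as the target, read by LC-MS, using microsomes, with a stated time of 30 min, tested at 1 uM (on this read-out lower numbers stand for slow clearance and higher numbers for fast clearance), and gave 17 mL.min-1.g-1. Compound 2 `O=C(Nc1cccnc1)N1CCc2ccccc2[C@H]1c1ccc(C(F)(F)F)cc1` carries pyridin-3-yl in place of 4-fluorophenyl on an amide-type nitrogen; in this assay compound 2 gives 95 mL.min-1.g-1, so that a 5.6-fold higher number from compound 1 to compound 2 (0.75 log units; beyond the scatter). Compound 3 `O=C(Nc1ccc(F)cc1)N1CCc2cccnc2[C@H]1c1ccc(C(F)(F)F)cc1` keeps the urea of compound 1 on a different core; the difference between the two cores is not broken down here. For compound 3 this assay reports only a limit, < 14 mL.min-1.g-1, which is the limit of < 14 mL.min-1.g-1 in this assay, at which 1 of the 3 values shown sits. Compound 4 `O=C(Nc1cccnc1)N1CCc2cccnc2[C@H]1c1ccc(C(F)(F)F)cc1` has not yet been measured; it carries pyridin-3-yl in place of 4-fluorophenyl on an amide-type nitrogen, the same change as that made from compound 1 to compound 2, at the same place on an amide-type nitrogen whose other neighbour is a carbonyl carbon. Among the compounds with values here, the measured step is the only guide here, and because compound 3 sits at the limit of < 14 mL.min-1.g-1 in this assay, at which 1 of the 3 values shown sits, its true starting value is unknown, which widens the range. Compound 4 is therefore expected to give about 40 mL.min-1.g-1 in this assay, between 14 mL.min-1.g-1 and 110 mL.min-1.g-1. The expected step for compound 4 is an at least 2.8-fold higher number from compound 3 to compound 4 (0.45 log units; beyond the scatter), modelled on the measured step of a 5.6-fold higher number from compound 1 to compound 2 (0.75 log units; beyond the scatter).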

Compound 4, intrinsic clearance in microsomes: 104 mL.min-1.g-1
Compound 4: middle estimate off by 2.6-fold (0.41 log units), on the low side, within the range that was stated.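

In this assay the swap of 4-fluorophenyl for pyridin-3-yl on the amide-type nitrogen again went with a rise on the second core, giving an at least 7.4-fold higher number from compound 3 to compound 4 (0.87 log units; beyond the scatter). The change therefore carried over in direction from the core of compound 1 to the core of compound 3, and the comparison of the two steps goes no further than this: the same change on two cores in this assay, a 5.6-fold higher number (0.75 log units; beyond the scatter) from compound 1 to compound 2 and an at least 7.4-fold higher number (0.87 log units; beyond the scatter) from compound 3 to compound 4; the limit leaves it open whether they differ. On these data alone, compound 3 stands at a limit of the assay and not at a number, so the size of its step remains open, and two cores are too few to establish a rule for the whole series: the limit of < 14 mL.min-1.g-1 in this assay, at which 1 of the 4 values shown sits.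

The compounds shown leave open how this assay would read with other groups on the amide-type nitrogen, such as an unsubstituted phenyl or a pyrimidinyl ring. They also leave open whether the same rise would appear if a nitrile or a chlorine atom took the place of the trifluoromethyl group.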